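A methylsulfonyl amide after two limit readings

A few compounds are considered here, and "the series" means these few. Any claim that something is new, unique, unknown or untested is made for them only; others in the source may bear on it.

Compound 1 `O=C(Nc1ccc(Cl)c(-c2nnc3c(Cl)cccn23)c1)c1ccc(Cl)cc1`: > 100000 nM
Compound 2 `O=C(Nc1ccc(Cl)c(-c2nnc3c(Cl)cccn23)c1)c1ccon1`: > 100000 nM

Both readings come from a functional assay on MDA-MB-468 cells (Homo sapiens) for antiproliferative activity, read by MTT assay, with a stated time of 72 h (on this read-out lower numbers stand for stronger inhibition and higher numbers for weaker inhibition), and neither is a number. In this assay compound 1 gives > 100000 nM, which is a limit. In this assay compound 2 gives > 100000 nM, which is also a limit. Compound 2 therefore has no exact position, and the data show only (the limit of > 100000 nM in this assay, at which 2 of the 2 values shown sit). Among the measured compounds shown here, the only measured step is a step that the two limits leave unreadable from compound 1 to compound 2. It gives no size to carry forward.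

Compound 3 `CS(=O)(=O)c1cccc(C(=O)Nc2ccc(Cl)c(-c3nnc4c(Cl)cccn34)c2)c1` has not yet been measured. It carries 3-(methylsulfonyl)phenyl in place of 1,2-oxazol-3-yl on a carbonyl carbon.

Two different groups at this place have so far given only limits, so no step beyond the scatter is expected in this assay. Another limit is the likeliest result. Any exact number could only point towards stronger inhibition, though nothing measured supports that direction. The expected step is a number no higher from compound 2 to compound 3 (the limit leaves the size open). Compound 3 is estimated at 100000 nM, with an expected range from 30000 nM to 200000 nM.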

Compound 3, half-maximal inhibitory concentration: > 100000 nM
Compound 3 gave a limit, no number (the forecaster's own chance of this, stated with the estimate: 75%); the middle value lies on the limit itself.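

In this assay compound 3 gives > 100000 nM, which is a limit. The steps to compound 3 from compound 1 and from compound 2 therefore cannot be read, and all three compounds stand at the same limit: the limit of > 100000 nM in this assay, at which 3 of the 3 values shown sit.

The compounds shown leave open how these three groups on a carbonyl carbon rank against one another, and whether any group at this place gives an exact number.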